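Swapping Propyl for Amino on the Core of Compound 2

This account rests on a few compounds, and the source may have more. Where it says the series, first, only, none or still open, it means among the compounds named here.

Within the data shown here, in a functional assay on the whole organism with Rattus norvegicus as the target, at a dose of 1 mg/kg by the oral route (a lower number here means a weaker effect, a higher number a stronger effect of the compound at the dose given), compound 2 `CCCc1ccc(-c2cc(Cl)cc(C(=O)Nc3nn[nH]n3)n2)cc1` gives 78%, the higher of the two numbers measured so far. Compound 1 `COc1ccc(-c2cc(Cl)cc(C(=O)Nc3nn[nH]n3)n2)cc1` carries methoxy where compound 2 carries propyl; in this assay compound 1 gives 43%. That step, a number 35 percentage points higher from compound 1 to compound 2 (beyond the scatter), is the only one measured, and it shows that the group on this aromatic carbon changes the read-out a great deal. Compound 3 `Nc1ccc(-c2cc(Cl)cc(C(=O)Nc3nn[nH]n3)n2)cc1` differs from compound 2 in one place: amino in place of propyl on an aromatic carbon. Among the measured compounds shown here, no measured compound carries amino, so the step to compound 3 can only be judged by analogy with methoxy, the other group seen at this position, which gave the lower number. For the measured compounds named here, because a number 35 percentage points higher from compound 1 to compound 2 (beyond the scatter) is the only known change away from propyl and, read backwards, it was a large loss, a drop beyond the scatter, a number 38 percentage points lower from compound 2 to compound 3 (beyond the scatter), is expected. Compound 3 is estimated to give 40%, with a range from 15% to 65%.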

Compound 3, a percentage reported as inhibition, in the whole organism at one dose (the size of the read-out at that dose, not a potency): 100%
Estimate against measurement, compound 3: 60 percentage points below; measured number above the stated range.
By their numbers in this assay, from the lowest: compound 1; then compound 2; then compound 3.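

Amino in place of propyl gives a number 22 percentage points higher from compound 2 to compound 3 (beyond the scatter) in this assay, so propyl is not the best group seen on this aromatic carbon, and amino, with 1 heavy atom against 3 for propyl, ranks above it. Amino in place of methoxy gives a number 57 percentage points higher from compound 1 to compound 3 (beyond the scatter) and places methoxy, propyl and amino in rising order, so the earlier step from methoxy to propyl can no longer be read as a gain from a larger group, since amino goes against that reading. Nothing available here explains why amino gives the highest number of the three.

From the compounds shown here alone, whether the gain depends on the hydrogens of the amino group stays open, and a methylamino or dimethylamino group in its place would test this. Going by these compounds, with compound 3 at 100% at a single dose, any further gain from a hydroxyl group or a carboxylic acid at this position also remains unknown.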